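The source may hold more compounds than are shown below. What is called first, only, known or untested is meant among the compounds shown, and "the series" means these compounds.

Compound 2, `Cc1nn(C)c2nc(NNC(=O)Nc3cc(Cl)nc(Cl)c3)cc(-c3ccc(F)cc3)c12`, sits among three measured compounds: compound 1, `CCN(CC)c1cc(NC(=O)NNc2cc(-c3ccc(F)cc3)c3cnn(C)c3n2)cc(Cl)n1`, and compound 3, `CC(C)c1cc(NNC(=O)Nc2cc(Cl)nc(Cl)c2)nc2c1cnn2C`. In an assay on isolated protein for binding affinity to sphingosine 1-phosphate receptor 2 (Homo sapiens), read by surface plasmon resonance (on this read-out higher numbers stand for weaker binding and lower numbers for tighter binding), compound 2 gives 980 nM. This is the second highest of the three numbers. Compound 3 gives 780 nM in this assay, a gap to compound 2 that lies within the scatter, while compound 1 gives 3150 nM in this assay, a gap beyond the scatter. The two compounds carrying dichloropyridinyl ureas, compound 2 and compound 3, therefore stand close together.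

Compound 4, `CCCc1cc(NNC(=O)Nc2cc(Cl)nc(Cl)c2)nc2c1c(C)nn2C`, has not been measured. It differs from compound 2 in one place: propyl in place of 4-fluorophenyl on an aromatic carbon. Where compound 2 carries 4-fluorophenyl, compound 3 carries isopropyl and gives 780 nM in this assay, a number within the scatter of compound 2, so a small alkyl group at this carbon appears to be tolerated. For compound 4 the expected step from compound 2 in this assay is a 1.0-fold higher number from compound 2 to compound 4 (0.01 log units; within the scatter), no change beyond the scatter. Compound 4 is estimated at 1000 nM in this assay, with a range from 400 nM to 2500 nM.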

Compound 4, dissociation constant: 2360 nM
The estimate for compound 4 lay 2.4-fold (0.37 log units) below the measured number, within the range that was stated.
By their numbers in this assay, from the lowest: compounds 3 and 2 (each within the scatter of the next); then compounds 4 and 1 (each within the scatter of the next).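

Within the data shown here, this is the first step in which only the group on this aromatic carbon, opposite the ring nitrogen, changes while the rest of the molecule stays the same. In this assay, propyl in place of 4-fluorophenyl gives a 2.4-fold higher number from compound 2 to compound 4 (0.38 log units; beyond the scatter), so this position is not indifferent to the change, although the step is modest and binding remains measurable without the aromatic ring. Nothing shown explains why the number rises.

A single exchange cannot separate the loss of the ring from the loss of the fluorine or from the change in size. Phenyl without fluorine, a longer chain such as hexyl, or an amine on this carbon could each help to tell these apart, and how far the step carries over to other ureas remains open.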